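Ring-nitrogen substituent swap in a cytotoxicity-silent series

A few compounds are considered here, and "the series" means these few. Any claim that something is new, unique, unknown or untested is made for them only; others in the source may bear on it.

Three compounds of this series have been run in an ADME assay on MT2 cells (Homo sapiens) for cytotoxicity, read by XTT assay, with a stated time of 4 days; a higher number here means that more compound is tolerated, a lower number that less compound is tolerated. Compound 1 `Cc1ccc(-c2c3c(nc(C)c2[C@H](OC(C)(C)C)C(=O)O)CCN(CCCc2ccccc2)C3)cc1` reports only a limit in this assay, > 40000 nM. Compound 2 `Cc1ccc(-c2c3c(nc(C)c2C(OC(C)(C)C)C(=O)O)CCN(S(C)(=O)=O)C3)cc1` likewise gives only a limit in this assay, > 40000 nM. Compound 3 `Cc1nc2c(c(-c3cc(F)c4c(c3C)CCCO4)c1[C@H](OC(C)(C)C)C(=O)O)CN(CCCc1cccc(F)c1)CC2` also stops at a limit in this assay, > 40000 nM. Compound 2 therefore stands where every measured member of the series stands, namely at the limit of > 40000 nM in this assay, at which 3 of the 3 values shown sit, with no number beneath that limit to set it apart from the others. No pair of these compounds differs in a single place, so no measured step is available to carry forward.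

Compound 4 `Cc1ccc(-c2c3c(nc(C)c2C(OC(C)(C)C)C(=O)O)CCN(C)C3)cc1` is the next member for this assay. Relative to compound 2 the change is methyl in place of methylsulfonyl on an amine nitrogen in a ring. The counted difference is small, and the three measured compounds, which differ in what sits on the amine nitrogen in a ring as well as elsewhere, all sit at the limit. The expected step of a number no higher from compound 2 to compound 4 (the limit leaves the size open) is none beyond the scatter, and the most likely outcome is another limit. Compound 4 is accordingly estimated at 40000 nM in this assay, with an expected range from 15000 nM to 80000 nM.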

Compound 4, half-maximal cytotoxic concentration: > 40000 nM
Compound 4 was reported as a limit; the forecaster's own chance of this, stated with the estimate: 75%; the middle value sits exactly at the limit.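

The step from compound 2 to compound 4, methyl in place of methylsulfonyl on an amine nitrogen in a ring, cannot be read in this assay, as both compounds report only a limit: the limit of > 40000 nM in this assay, at which 4 of the 4 values shown sit.

The compounds shown leave open how far apart any of them lie, and whether any substituent on that nitrogen changes tolerance at all.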